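Shifting the methyl along the diene of compound 3

A few compounds are considered here, and "the series" means these few. Any claim that something is new, unique, unknown or untested is made for them only; others in the source may bear on it.

Compound 1 `C=C/C=C/[C@](C)(O)C/C=C/[C@H]1[C@H](O)CC(=O)[C@@H]1CC/C=C\CCC(=O)OC` carries an unsubstituted buta-1,3-dien-1-yl at the hydroxylated chain carbon; in a functional assay on the whole organism with Rattus norvegicus as the target (a lower number here means that less compound is needed, a higher number that more compound is needed for the effect), compound 1 gives 0.243 mg/kg. Compound 2 `COC(=O)CC/C=C\CC[C@H]1C(=O)C[C@@H](O)[C@@H]1/C=C/C[C@@](C)(O)/C=C/C(C)=C(C)C` and compound 3 `C=C/C=C(\C)[C@](C)(O)C/C=C/[C@H]1[C@H](O)CC(=O)[C@@H]1CC/C=C\CCC(=O)OC` each add methyl substitution to that chain. For compound 2 the assay reports only a limit, > 3.16 mg/kg. For compound 3 likewise only a limit is known, > 3.16 mg/kg. Both steps from the parent are large: an at least 13-fold higher number from compound 1 to compound 2 (1.11 log units; beyond the scatter) and an at least 13-fold higher number from compound 1 to compound 3 (1.11 log units; beyond the scatter). The step that the two limits leave unreadable from compound 2 to compound 3 cannot be read, since both ends sit at the same boundary (the limit of > 3.16 mg/kg in this assay, at which 2 of the 3 values shown sit). Compound 3 therefore stands at the weak end of what has been measured, with no number of its own.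

Compound 4 `C=C/C(C)=C/[C@](C)(O)C/C=C/[C@H]1[C@H](O)CC(=O)[C@@H]1CC/C=C\CCC(=O)OC` is the next step: 2-methylbuta-1,3-dien-1-yl in place of 1-methylbuta-1,3-dien-1-yl on a saturated chain carbon bound to an oxygen on a saturated carbon and two saturated chain carbons. For the measured compounds named here, no measured pair tests this exact rearrangement. The two steps that bear on it, from compound 1 to compound 2 and from compound 1 to compound 3, show that methyl substitution on the diene, in two different patterns, pushed this assay to its limit each time. Compound 4 keeps a methyl on the diene, so a number near or at the limit is expected for compound 4, estimated at 2.5 mg/kg (range 0.6 mg/kg to 10 mg/kg); the expected step is an at least 1.2-fold lower number from compound 3 to compound 4 (0.10 log units; that floor lies within the scatter).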

Compound 4, dose for half-maximal effect: 1.03 mg/kg
Estimate against measurement, compound 4: 2.4-fold (0.39 log units) above, and the stated range covers the measured number.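

The same atoms, rearranged from 1-methylbuta-1,3-dien-1-yl to 2-methylbuta-1,3-dien-1-yl on the saturated chain carbon, give an at least 3.0-fold lower number from compound 3 to compound 4 (0.48 log units; beyond the scatter), so in this assay a methyl on the diene does not by its presence alone lead to the limit; where it sits on the diene counts in this pair. The methyl in the 2-methylbuta-1,3-dien-1-yl group is still not free of cost against the unsubstituted buta-1,3-dien-1-yl, with a 4.2-fold higher number from compound 1 to compound 4 (0.63 log units; beyond the scatter). Against the 3,4-dimethylpenta-1,3-dien-1-yl group the result reads an at least 3.0-fold lower number from compound 2 to compound 4 (0.48 log units; beyond the scatter), and this step and the one from the 1-methyl isomer are floors, as compound 2 and compound 3 are held only by a limit: the limit of > 3.16 mg/kg in this assay, at which 2 of the 4 values shown sit.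

From the compounds shown here alone, the full size of the gain from the rearrangement stays open, as neither compound 2 nor compound 3 has a number of its own. Also open, going by these compounds, is whether an ethyl or a hydroxymethyl in place of the methyl of the 2-methylbuta-1,3-dien-1-yl group would read closer to compound 1 or closer to the limit in this assay.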